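A few compounds are considered here, and "the series" means these few. Any claim that something is new, unique, unknown or untested is made for them only; others in the source may bear on it.

Measured so far:
- compound 1 `O=C(OCc1ccccc1)c1cccc(=O)[nH]1`: 69000 nM in an assay on isolated protein for inhibition of matrix metalloproteinase-9 (Homo sapiens); a lower number here means a stronger inhibitor, a higher number a weaker inhibitor
- compound 2 `O=C(OCc1cccc(Oc2ccccc2)c1)c1cccc(=O)[nH]1`: > 150 nM, a limit of this assay

Compound 1 is the only compound with a number shown; the other value is a limit. Compound 3 `O=C(OCc1ccc(Cl)cc1)c1cccc(=O)[nH]1` has not been measured. It differs from compound 1 by chloro in place of hydrogen on an aromatic carbon.

Among the compounds with values here, the only measured step, a step that the limit leaves unreadable from compound 1 to compound 2, replaces a hydrogen on the same aromatic ring with phenoxy, but because the limit of > 150 nM in this assay, at which 1 of the 2 values shown sits, its size cannot be read. It therefore gives no guide to the size of a chloro change. Within the data shown here, no other measured step bears on the change from compound 1 to compound 3.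

With no readable step to lean on, the expectation for compound 3 is a step of a 1.4-fold lower number from compound 1 to compound 3 (0.14 log units; within the scatter), within the scatter. Compound 3 is estimated at 50000 nM, between 15000 nM and 150000 nM.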

Compound 3, half-maximal inhibitory concentration: 68000 nM
For compound 3 the middle estimate is 1.4-fold (0.13 log units) below the measured one; measured number inside the range.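

In this assay, placing chloro on the aromatic carbon para to a large group gives a 1.0-fold lower number from compound 1 to compound 3 (0.01 log units; within the scatter). Within the data shown here, this is the first step on this ring whose size can be read, and it shows that adding this single chlorine atom at this position produces no change distinguishable from the scatter. The value for compound 2 is a limit, so its step from compound 1 still cannot be read: the limit of > 150 nM in this assay, at which 1 of the 3 values shown sits.

One chloro result says nothing about how an amine, a carboxylic acid or a longer chain would behave at this same position. It also leaves open whether chloro elsewhere on the ring would give a similar result, or whether a group on the shared core outside this ring would move the number further.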